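Hydrazone series: swapping one hydroxy for tert-butyl

The compounds below may be only part of what the source reports. "The series", "measured", "known", "first", "only" and "open" are said of these compounds alone.

Compound 1 `O=C(N/N=C/c1ccc(O)cc1)c1ccc(O)cc1` carries a hydroxy on each of its two aromatic rings. In a physicochemical assay, read by spectrophotometry, with a stated time of 60 min, tested at 1000 uM (on this read-out lower numbers stand for a weaker effect and higher numbers for a stronger effect at the one concentration tested), compound 1 gives 65%, the higher of the two numbers in hand. Compound 2 `COc1ccc(/C=C/C=N/NC(=O)c2ccc(C(C)(C)C)cc2)cc1` has no hydroxy and a tert-butyl in its place; in this assay compound 2 gives 7.1%, a gap to compound 1 that lies well beyond the scatter. Among the measured compounds shown here, no pair of measured compounds differs in one place only, so no single step is known.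

Compound 3 `CC(C)(C)c1ccc(C(=O)N/N=C/c2ccc(O)cc2)cc1` is not yet measured. It differs from compound 1 by tert-butyl in place of hydroxy on an aromatic carbon, keeping the hydroxy on the other ring. A drop beyond the scatter is expected, because compound 2, which also carries tert-butyl and no hydroxy on that ring, gives 7.1%, while the remaining hydroxy of compound 3 argues against a fall all the way to that level. The expected step from compound 1 to compound 3 is a number 30 percentage points lower from compound 1 to compound 3 (beyond the scatter). For compound 3 the estimate in this assay is 35%, with a range of 15% to 55%.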

Compound 3, a percentage reported as inhibition, at one concentration (the size of the read-out at that concentration, not a potency): 38.7%
The estimate for compound 3 lay 3.7 percentage points below the measured number, within the range that was stated.
By their numbers in this assay, from the lowest: compound 2; then compound 3; then compound 1.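

Among the compounds shown here, replacing hydroxy with tert-butyl on an aromatic carbon, para to a large group, gives in this assay a number 26.3 percentage points lower from compound 1 to compound 3 (beyond the scatter) as the first single-place step. The hydroxy at this position is therefore not required for a read-out in this assay: compound 3 still gives 38.7% with tert-butyl there and the hydroxy on the other ring kept. No available data explain the size of this step.

The compounds shown do not separate the loss of the hydroxy from the entry of the tert-butyl, and an amine or a carboxylic acid at this position would be needed to test how the read-out depends on the group placed there. For the compounds shown here, the contribution of the hydroxy on the other ring also remains open, with no single-place step to define it.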